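Imidazopyrazine series: aryl swap on the shared core

This account rests on a few compounds, and the source may have more. Where it says the series, first, only, none or still open, it means among the compounds named here.

Measured so far:
- compound 1, `CC(=O)c1ccc(-c2cn3ccnc3c(-c3ccc4ncn(C5CCCCC5)c4c3)n2)cc1`: 12% in a functional assay on MCF7 cells (Homo sapiens) for inhibition, read by sulforhodamine B assay, with a stated time of 48 h, tested at 10 uM; on this read-out higher numbers stand for more inhibition at the one concentration tested (going by the name of the read-out) and lower numbers for less inhibition
- compound 2, `CCc1ccc(-c2cn3ccnc3c(-c3ccc4ncn(Cc5ccccc5)c4c3)n2)cc1`: 58% in this assay

Compound 2 stands highest of the two numbers; its nearest neighbour, compound 1, sits a number lower that lies beyond the scatter. Within the data shown here, compound 1 and compound 2 differ in two places, so no single step between them can be read from their values; only the two numbers themselves are known.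

The next compound, compound 3, `Cc1cccc(-c2cn3ccnc3c(-c3ccc4ncn(Cc5ccccc5)c4c3)n2)c1`, keeps the benzyl group of compound 2 and changes the other aryl group: 3-methylphenyl in place of 4-ethylphenyl on an aromatic carbon. The change exchanges one six-membered carbon ring for another of nearly the same size, with no donors or acceptors on either side. Among the measured compounds shown here, no measured step of this kind exists in the set, so the expected size of a number 10 percentage points lower from compound 2 to compound 3 (within the scatter) is small, most likely none beyond the scatter, with a slight lean towards less inhibition.

Compound 3 is therefore expected to give about 48% in this assay, within a range of 25% to 70%.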

Compound 3, a percentage reported as inhibition, at one concentration (the size of the read-out at that concentration, not a potency): 22.2%
Compound 3: the middle estimate sits 25.8 percentage points above what was measured, and the stated range ends above it.
By their numbers in this assay, from the lowest: compound 1; then compound 3; then compound 2.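

Among these compounds, this is the first step that changes one place only, and it shows that the aryl position on the shared core is sensitive in this assay: 3-methylphenyl in place of 4-ethylphenyl gives a number 35.8 percentage points lower from compound 2 to compound 3 (beyond the scatter), with the benzyl group held constant. Both groups have one six-membered aromatic ring of carbon only and no hydrogen-bond donors or acceptors, so those counts do not have to differ for the read-out to move beyond the scatter. Nothing at hand accounts for the size of this step.

The step changes the alkyl chain and its place on the ring together, so the contribution of each stays unresolved, and steps involving compound 1 cannot be read, since it differs from each of the other two compounds in two places. Also open, going by these compounds, is how this position would respond to an unsubstituted phenyl, a longer chain such as propyl, an amine or a carboxylic acid, and whether any of these would match or pass compound 2 at 58%.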